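Ring-nitrogen swap on the anilino group: expected outcome

The compounds below may be only part of what the source reports. "The series", "measured", "known", "first", "only" and "open" are said of these compounds alone.

Compound 1 `COc1ccc(Nc2nc(Oc3cccc(NC(=O)C=C(C)C)c3)c3sccc3n2)cc1` gives 28800 nM in a functional assay on HeLa cells (Homo sapiens) for inhibition, read by MTT assay, with a stated time of 72 h; a lower number here means a stronger inhibitor, a higher number a weaker inhibitor.
Compound 2 `COc1ccc(Nc2nc(Oc3cccc(NC(=O)/C=C/C(C)C)c3)c3sccc3n2)cc1` gives 45100 nM in this assay.
Compound 3 `COc1cccc(Nc2nc(Oc3cccc(NC(=O)C=C(C)C)c3)c3sccc3n2)c1` gives 26100 nM in this assay.

Compound 2 holds the highest of the three numbers, yet its gaps to compound 1 and compound 3 are both within the scatter. The two measured steps are a 1.6-fold higher number from compound 1 to compound 2 (0.19 log units; within the scatter) and a 1.1-fold lower number from compound 1 to compound 3 (0.04 log units; within the scatter), the second of these being the only one that touches the methoxyphenyl group on the ring nitrogen. Compound 4 `COc1ccc(Nc2nc(Oc3cccc(NC(=O)/C=C/C(C)C)c3)c3sccc3n2)cn1` differs from compound 2 by 6-methoxypyridin-3-yl in place of 4-methoxyphenyl on a nitrogen on an aromatic ring. Among the measured compounds shown here, no measured step replaces a ring carbon with nitrogen at this place, so the guide is the within-scatter step from compound 1 to compound 3. For compound 4 a step of a 1.1-fold lower number from compound 2 to compound 4 (0.03 log units; within the scatter) is expected, no change beyond the scatter. Compound 4 is therefore estimated at 42000 nM, between 15000 nM and 120000 nM.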

Compound 4, half-maximal inhibitory concentration: > 50000 nM
Compound 4: only a limit was reported; the forecaster's own chance of this, stated with the estimate: 15%; middle value at least 1.1-fold (0.07 log units) away from the limit.
By their numbers in this assay, from the lowest: compounds 3, 1 and 2 (each within the scatter of the next). At a limit, above all of these: compound 4.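

In this assay compound 4 is reported only as a limit, > 50000 nM, and not as a number. The change to 6-methoxypyridin-3-yl on a nitrogen on an aromatic ring, the first ring nitrogen at this place, gives an at least 1.1-fold higher number from compound 2 to compound 4 (0.04 log units; that floor lies within the scatter). Only the floor of this step is known, so its true size remains open: the limit of > 50000 nM in this assay, at which 1 of the 4 values shown sits.

Still open, as far as these compounds go, is whether this ring nitrogen gives a similar step with the 2-methylprop-1-en-1-yl group of compound 1 on the carbonyl carbon. Also open, from the compounds shown here alone, is what an amine or a carboxylic acid would do in place of the methoxy group on this ring.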